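From hydroxy to dimethylamino on the side chain

The source may report more compounds than this note shows. Statements on the series, on what has been measured and on what is new or still open speak of the compounds shown alone.

Compound 1 `COc1ccc(C(=O)c2ccc(OC)c3c2C=CC(C)(C)O3)c(NC(=O)CO)c1` gives 310 nM
Compound 2 `C=C(c1ccc(OC)cc1NC(=O)CO)c1ccc(OC)c2c1OC(C)(C)C=C2` gives 40 nM

In a functional assay on HeLa cells (Homo sapiens) for antiproliferative activity, read by MTT assay, with a stated time of 48 h (on this read-out lower numbers stand for stronger inhibition and higher numbers for weaker inhibition), compound 2 at 40 nM has the lower of the two numbers, with compound 1 higher by more than the scatter. Compound 3 `C=C(c1ccc(OC)cc1NC(=O)CN(C)C)c1ccc(OC)c2c1OC(C)(C)C=C2` differs from compound 2 by one change dimethylamino in place of hydroxy on a saturated chain carbon bound to a carbonyl carbon with dimethylamino in place of hydroxy on a saturated chain carbon bound to a carbonyl carbon. Within the data shown here, no measured pair shows this change, so a small step towards weaker inhibition in this assay is expected, perhaps none beyond the scatter. The expected step is a 1.5-fold higher number from compound 2 to compound 3 (0.18 log units; within the scatter) on this estimate. The estimated value for compound 3 is 60 nM within a range of 15 nM to 250 nM as expected here.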

Compound 3, half-maximal inhibitory concentration: 900 nM
Beside the measured number, compound 3's estimate is 15-fold (1.18 log units) below it; the measured number lies above the stated range.
By their numbers in this assay, from the lowest: compound 2; then compound 1; then compound 3.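

In this assay, the saturated chain carbon bound to a carbonyl carbon proves sensitive to its substituent: dimethylamino in place of hydroxy gives a 23-fold higher number from compound 2 to compound 3 (1.35 log units; beyond the scatter). The change replaces one heavy atom with three and removes a hydrogen-bond donor, and the pair cannot separate these differences. Nothing available explains the loss. Still open, from the compounds shown here alone, is whether a primary amine, a methoxy group or a longer chain carrying hydroxy at this place would match compound 2. Going by these compounds, whether the same change has a similar effect on the core of compound 1 also stays open.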